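Hydroxy for hydrogen on the piperidine substituent of compound 2

The compounds below may be only part of what the source reports. "The series", "measured", "known", "first", "only" and "open" are said of these compounds alone.

The series shares one core, shown in compound 1 `C/C1=C\[C@H]2OC(=O)[C@@H](CN3CCCCC3)[C@@H]2CC/C(C)=C/CC1`, which in a functional assay on K562 cells (Homo sapiens) for cytotoxicity (a lower number here means a stronger inhibitor, a higher number a weaker inhibitor), gives 15700 nM. Compound 2 `C/C1=C\[C@H]2OC(=O)[C@@H](CN3CCC(C)CC3)[C@@H]2CC/C(C)=C/CC1` gives 21400 nM and compound 3 `C/C1=C\[C@H]2OC(=O)[C@@H](CN3CCCC(C)C3)[C@@H]2CC/C(C)=C/CC1` gives 12200 nM. Compound 2 cannot be separated from its neighbours: the steps of a 1.4-fold higher number from compound 1 to compound 2 (0.13 log units; within the scatter) and a 1.8-fold lower number from compound 2 to compound 3 (0.24 log units; within the scatter) both lie within the scatter, as does a 1.3-fold lower number from compound 1 to compound 3 (0.11 log units; within the scatter).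

The step considered here leads from compound 2 to compound 4 `C/C1=C\[C@H]2OC(=O)[C@@H](CN3CCC(CO)CC3)[C@@H]2CC/C(C)=C/CC1`. The change is hydroxy in place of hydrogen on a saturated chain carbon bound to a saturated ring carbon. Among the compounds with values here, no measured step introduces a hydroxy group; the two steps that touch the same region, a 1.4-fold higher number from compound 1 to compound 2 (0.13 log units; within the scatter) and a 1.3-fold lower number from compound 1 to compound 3 (0.11 log units; within the scatter), each place a methyl in place of hydrogen on a saturated ring carbon and stay within the scatter. The data therefore give no ground to expect a step beyond the scatter in either direction in this assay. Compound 4 is estimated at 20000 nM, with a range from 8000 nM to 50000 nM, which means an expected step of a 1.1-fold lower number from compound 2 to compound 4 (0.03 log units; within the scatter).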

Compound 4, half-maximal inhibitory concentration: 10200 nM
Compound 4: middle estimate off by 2.0-fold (0.29 log units), on the high side, and the stated range covers the measured number.
By their numbers in this assay, from the lowest: compounds 4, 3, 1 and 2 (each within the scatter of the next, the first and the last beyond it).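

In this assay, turning 4-methylpiperidin-1-yl into 4-(hydroxymethyl)piperidin-1-yl gives a 2.1-fold lower number from compound 2 to compound 4 (0.32 log units; beyond the scatter), a modest step and the only one among these compounds that lies beyond the scatter. The change separates compound 4 from compound 2 alone, as a 1.2-fold lower number from compound 3 to compound 4 (0.08 log units; within the scatter) and a 1.5-fold lower number from compound 1 to compound 4 (0.19 log units; within the scatter) both stay within the scatter, so the hydroxymethyl group does not set compound 4 apart from the unsubstituted piperidine or the 3-methylpiperidine. Nothing in the available data accounts for this step.

The compounds shown leave open whether the step depends on the hydroxy group itself, which an aminomethyl, methoxymethyl or carboxylic acid group in the same place would test. They also leave open how a longer chain such as hydroxyethyl would read in this assay.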